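Homologation of the ethyl group in a triazole series

This account rests on a few compounds, and the source may have more. Where it says the series, first, only, none or still open, it means among the compounds named here.

Compound 1, `C=CCSc1nnc(CC)n1N1C(=O)c2ccccc2C1=O`, in a functional assay on PC-3M cells (Homo sapiens) for cytotoxicity, read by MTT assay, with a stated time of 48 h (a lower number here means a stronger inhibitor, a higher number a weaker inhibitor), reaches only the limit > 200000 nM.
Compound 2, `CCc1nnc(SCc2ccccc2)n1N1C(=O)c2ccccc2C1=O`, gives in this assay only the limit > 200000 nM.
Compound 3, `CCc1nnc(SCC(=O)c2ccc(Cl)cc2)n1N1C(=O)c2ccccc2C1=O`, gives in this assay only the limit > 200000 nM.

Compound 2 therefore stands at a limit, as do the two other measured compounds (the limit of > 200000 nM in this assay, at which 3 of the 3 values shown sit). The steps a step that the two limits leave unreadable from compound 1 to compound 2, a step that the two limits leave unreadable from compound 1 to compound 3 and a step that the two limits leave unreadable from compound 2 to compound 3 stay unreadable, since both ends of each sit at that limit. Compound 4, `CCCc1nnc(SCc2ccccc2)n1N1C(=O)c2ccccc2C1=O`, differs from compound 2 by methyl in place of hydrogen on a saturated chain carbon, two bonds along the chain from an aromatic carbon. Among the compounds with values here, none of the measured steps concerns this part of the molecule, and none has a readable size, so no direction can be drawn from them; with every measured compound at the limit, compound 4 is expected to remain there too, a step that the limit leaves unreadable from compound 2 to compound 4 that would again be unreadable. Compound 4 is estimated at 400000 nM, within 150000 nM to 2000000 nM.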

Compound 4, half-maximal inhibitory concentration: > 200000 nM
Compound 4: no number, only a limit; the forecaster's own chance of this, stated with the estimate: 85%; the middle value is on the limit's open side.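

Compound 4 sits at the same limit as compound 2, so no new step can be read between them: the limit of > 200000 nM in this assay, at which 4 of the 4 values shown sit. The compounds shown leave open whether any change to these chains alters potency in this assay.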